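The source may report more compounds than this note shows. Statements on the series, on what has been measured and on what is new or still open speak of the compounds shown alone.

In an ADME assay on MT4 cells (Homo sapiens) for cytotoxicity, read by MTT assay, with a stated time of 96 h (on this read-out higher numbers stand for lower toxicity in this test and lower numbers for higher toxicity in this test), two compounds sharing one core have been measured so far. Compound 1 `CC(=O)c1ccc2c(c1)nc(-c1ccc(Cl)cc1)n2C1CCCCC1` gives 58000 nM, and compound 2 `COc1ccc(-c2nc3cc(C(C)=O)ccc3n2C2CCCCC2)cc1` gives 27000 nM, the lower of the two numbers. Compound 3 `CC(=O)c1ccc2c(c1)nc(-c1ccoc1)n2C1CCCCC1` has furan-3-yl in place of 4-methoxyphenyl on an aromatic carbon of the five-membered aromatic ring with 2 nitrogen: furan-3-yl in place of 4-methoxyphenyl on an aromatic carbon. Going by the values given here, the only measured change at this place is a 2.1-fold lower number from compound 1 to compound 2 (0.33 log units; beyond the scatter), a modest step made by methoxy in place of chloro on an aromatic carbon. That step kept the six-membered ring, whereas this one replaces it, so it offers only a loose guide. A small move towards compound 1 at 58000 nM is expected, no larger than that measured step. The expected change is a 1.7-fold higher number from compound 2 to compound 3 (0.22 log units; within the scatter). For compound 3 the estimated value is 45000 nM, with an expected range of 18000 nM to 110000 nM.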

Compound 3, half-maximal cytotoxic concentration: 63000 nM
Estimate against measurement, compound 3: 1.4-fold (0.15 log units) below; measured number inside the range.
By their numbers in this assay, from the lowest: compound 2; then compounds 1 and 3 (each within the scatter of the next).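

At this position, on the aromatic carbon between two ring nitrogen atoms, the six-membered aromatic ring of carbon only can give way to a five-membered aromatic ring with 1 hetero atom without the number dropping in this assay: furan-3-yl in place of 4-methoxyphenyl gives a 2.3-fold higher number from compound 2 to compound 3 (0.37 log units; beyond the scatter) and so a modest move towards lower toxicity in this test. Furan-3-yl in place of 4-chlorophenyl gives a 1.1-fold higher number from compound 1 to compound 3 (0.04 log units; within the scatter) and stays within the scatter, so compound 1 and compound 3 cannot be told apart, and only compound 2 stands apart from the others. Nothing available explains why the 4-methoxyphenyl group differs from the other two groups.

From the compounds shown here alone, whether the number holds with an amine or a carboxylic acid at this position remains open. So does the effect of a non-aromatic ring such as morpholine there.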